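Thiazolylmethyl in Place of Ethoxyethyl: Cytotoxicity Expectation

The compounds below may be only part of what the source reports. "The series", "measured", "known", "first", "only" and "open" are said of these compounds alone.

Compound 1 `Nc1nc(Cl)c(-c2nccs2)c(N[C@@H]2C[C@H](CO)[C@@H](O)[C@H]2O)n1`: > 25000 nM
Compound 2 `CNc1nc(C)c(-c2nc3ccccc3s2)c(N[C@@H]2C[C@H](CO)[C@@H](O)[C@H]2O)n1`: > 25000 nM
Compound 3 `CCOCCNc1nc(C)c(-c2nc3ccccc3s2)c(N[C@@H]2C[C@H](CO)[C@@H](O)[C@H]2O)n1`: 18000 nM

Among the compounds with values here, in an ADME assay on cells (Homo sapiens) for cytotoxicity, read by polymerase chain reaction, with a stated time of 3 days (a higher number here means that more compound is tolerated, a lower number that less compound is tolerated), compound 3 gives 18000 nM, the only actual number among the three. Compound 1 reaches only a limit of the assay, > 25000 nM. Compound 2 likewise reaches only a limit, > 25000 nM. Two of the three values thus sit at the limit of > 25000 nM in this assay, at which 2 of the 3 values shown sit, so compound 3 is the one fixed point. Compound 4 `Cc1nc(NCc2nccs2)nc(N[C@@H]2C[C@H](CO)[C@@H](O)[C@H]2O)c1-c1nc2ccccc2s1` differs from compound 3 by 1,3-thiazol-2-yl in place of ethoxymethyl on a saturated chain carbon bound to a nitrogen on an aromatic ring. Within the data shown here, the one measured step at the same place, an at least 1.3-fold lower number from compound 2 to compound 3 (0.14 log units; that floor lies within the scatter), stays within the scatter, and it offers no guide to a change of a different kind. No step beyond the scatter is therefore expected in this assay. Compound 4 is expected to give 20000 nM, between 8000 nM and 60000 nM. That estimate means a step of a 1.1-fold higher number from compound 3 to compound 4 (0.05 log units; within the scatter).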

Compound 4, half-maximal cytotoxic concentration: 23000 nM
The estimate for compound 4 lay 1.2-fold (0.06 log units) below the measured number; the measured number falls inside the stated range.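

In this assay, an aromatic ring, 1,3-thiazol-2-yl, can take the place of the open ethoxymethyl end on this saturated chain carbon without a step beyond the scatter (a 1.3-fold higher number from compound 3 to compound 4 (0.11 log units; within the scatter)). Against hydrogen at the same place, only a floor can be read (an at least 1.0-fold lower number from compound 2 to compound 4 (0.03 log units; that floor lies within the scatter)). So this position has now taken both a ring and an ether chain with no step beyond the scatter, though each rests on a single compound.

Going by these compounds, whether an amine or a carboxylic acid on this carbon would move the number beyond the scatter stays open. So does the effect of a longer chain.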